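A few compounds are considered here, and "the series" means these few. Any claim that something is new, unique, unknown or untested is made for them only; others in the source may bear on it.

In a functional assay on HCT-116 cells (Homo sapiens) for antiproliferative activity, read by MTT assay, with a stated time of 48 h (a higher number here means a weaker inhibitor, a lower number a stronger inhibitor), compound 2 (`CCCCCC(CCO)n1cnc2c(N(C)C)ncnc21`) gives > 50000 nM as a limit and not a number. Compound 1 (`CCCCCC(CCO)n1cnc2c(NC)ncnc21`) gives > 50000 nM as a limit too. Compound 3 (`CCCCCC(CCO)n1cnc2cncnc21`) gives > 50000 nM as a limit too. The whole record is the limit of > 50000 nM in this assay, at which 3 of the 3 values shown sit, and nothing finer. Compound 4 (`CCCCCCCCC(CCO)n1cnc2c(N(C)C)ncnc21`) lengthens the chain of compound 2, with propyl in place of hydrogen on a saturated chain carbon, six bonds along the chain from an aromatic nitrogen. Among the measured compounds shown here, none of the measured steps touches that chain, and a step that the two limits leave unreadable from compound 1 to compound 2 and a step that the two limits leave unreadable from compound 1 to compound 3 and a step that the two limits leave unreadable from compound 2 to compound 3 all stay without a size. They offer nothing to carry over, so only a weak expectation remains in this assay of a shift toward a stronger inhibitor. The expected step is an at least 1.2-fold lower number from compound 2 to compound 4 (0.09 log units; that floor lies within the scatter) and it is modest. For compound 4 the estimate is 40000 nM with an expected range from 15000 nM to 80000 nM and a fair chance of only a limit.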

Compound 4, half-maximal inhibitory concentration: 19800 nM
The estimate for compound 4 lay 2.0-fold (0.31 log units) above the measured number; the measured number falls inside the stated range.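

In this assay, this chain position gives the first readable step among the compounds shown: propyl in place of hydrogen on a saturated chain carbon, six bonds along the chain from an aromatic nitrogen, gives an at least 2.5-fold lower number from compound 2 to compound 4 (0.40 log units; beyond the scatter). The steps among compound 1, compound 2 and compound 3 cannot be read, and the rest of the record remains a limit: the limit of > 50000 nM in this assay, at which 3 of the 4 values shown sit. On these data alone, it remains open whether a longer chain than that of compound 4 would lower the number further. As far as these compounds go, a phenyl group at the same carbon also remains untested here, as does the same propyl change on compound 1.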